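The source may report more compounds than this note shows. Statements on the series, on what has been measured and on what is new or still open speak of the compounds shown alone.

In a functional assay on the whole organism for agonist activity, with Mus musculus as the target (a higher number here means that more compound is needed for the effect, a lower number that less compound is needed), compound 2 (`CCOC(=O)N(C)CC#CCN1CCCC1`) gives > 100 mg/kg, which is a limit of the assay and not a number. Compound 1 (`COC(=O)N(C)CC#CCn1ccnc1`), which carries 1H-imidazol-1-yl, gives 4.5 mg/kg in this assay. Compound 3 (`CCOC(=O)N(C)CC#CCn1ccnc1`) follows from compound 2 with 1H-imidazol-1-yl in place of pyrrolidin-1-yl on a saturated chain carbon bound to a triple-bonded carbon. For the measured compounds named here, no measured step isolates this change, yet a clear fall in the dose needed is expected, resting on compound 1 at 4.5 mg/kg. The expected size is an at least 11-fold lower number from compound 2 to compound 3 (1.04 log units; beyond the scatter). For compound 3 the estimate is 9 mg/kg, with an expected range of 3 mg/kg to 35 mg/kg.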

Compound 3, dose for half-maximal effect: > 100 mg/kg
Compound 3: no number, only a limit; the forecaster's own chance of this, stated with the estimate: 10%; middle value at least 11-fold (1.04 log units) from the limit.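

In this assay a single change, methyl in place of hydrogen on a saturated chain carbon bound to an oxygen next to a carbonyl group, gives an at least 22-fold higher number from compound 1 to compound 3 (1.34 log units; beyond the scatter) and so separates a measurable dose from the limit of the assay. 1H-imidazol-1-yl therefore does not carry the effect on its own. The step between compound 2 and compound 3 cannot be read because both values are limits and not numbers: the limit of > 100 mg/kg in this assay, at which 2 of the 3 values shown sit.

Open, going by these compounds, is whether pyrrolidin-1-yl gives a measurable dose on the core of compound 1. Also open, on these data alone, is how a propyl chain at this carbon would compare.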